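Anilino variation on a shared core: compound 3 to compound 4

This account rests on a few compounds, and the source may have more. Where it says the series, first, only, none or still open, it means among the compounds named here.

Measured so far in a functional assay on MGC-803 cells (Homo sapiens) for inhibition, read by sulforhodamine B assay; a lower number here means a stronger inhibitor, a higher number a weaker inhibitor:
Compound 1, `Cc1ccc(NC2=CC(=O)c3nc4n(c3C2=O)[C@H]2OC[C@@H](O)[C@H]2OC4)cc1C`, gives 860 nM.
Compound 2, `O=C1C=C(Nc2ccccc2)C(=O)c2c1nc1n2[C@H]2OC[C@@H](O)[C@H]2OC1`, gives 1730 nM.
Compound 3, `CCOc1ccc(NC2=CC(=O)c3nc4n(c3C2=O)[C@H]2OC[C@@H](O)[C@H]2OC4)cc1`, gives 1110 nM.

Compound 3 stands second highest of the three numbers. Its nearest neighbour is compound 1, with a 1.3-fold higher number from compound 1 to compound 3 (0.11 log units; within the scatter); its furthest is compound 2, with a 1.6-fold lower number from compound 2 to compound 3 (0.19 log units; within the scatter). Neither gap is beyond the scatter, so the three compounds are not separated.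

Compound 4, `COc1ccccc1NC1=CC(=O)c2nc3n(c2C1=O)[C@H]1OC[C@@H](O)[C@H]1OC3`, is not yet measured. Its change from compound 3 is 2-methoxyphenyl in place of 4-ethoxyphenyl on an amine nitrogen. All three known steps also exchange the aryl group on the same amine nitrogen: a 2.0-fold higher number from compound 1 to compound 2 (0.30 log units; within the scatter), a 1.3-fold higher number from compound 1 to compound 3 (0.11 log units; within the scatter) and a 1.6-fold lower number from compound 2 to compound 3 (0.19 log units; within the scatter). Each lies within the scatter, so this position has tolerated phenyl, 3,4-dimethylphenyl and 4-ethoxyphenyl without a clear change. Among the compounds with values here, no measured compound carries a 2-methoxyphenyl, so nothing beyond the scatter is expected in either direction for compound 4.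

Compound 4 is therefore estimated at 1300 nM, between 600 nM and 3000 nM. This expected outcome corresponds to a 1.2-fold higher number from compound 3 to compound 4 (0.07 log units; within the scatter).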

Compound 4, half-maximal inhibitory concentration: 1630 nM
For compound 4 the middle estimate is 1.3-fold (0.10 log units) below the measured one, and the stated range covers the measured number.
By their numbers in this assay, from the lowest: compounds 1, 3, 4 and 2 (each within the scatter of the next).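

In this assay, the 2-methoxyphenyl group of compound 4 joins phenyl, 3,4-dimethylphenyl and 4-ethoxyphenyl on the amine nitrogen without separating from any of them, with a 1.5-fold higher number from compound 3 to compound 4 (0.17 log units; within the scatter) and a 1.1-fold lower number from compound 2 to compound 4 (0.03 log units; within the scatter) and also a 1.9-fold higher number from compound 1 to compound 4 (0.28 log units; within the scatter) in this series. The range of aryl groups tolerated at this position therefore now includes a methoxy-bearing ring, and all four compounds remain unresolved from one another. No supporting data bear on this result.

The compounds shown carry only hydrogen, methyl, methoxy or ethoxy on the aryl ring, so an amine, a carboxylic acid or a halogen such as fluorine there remains open. Also open, going by these compounds, is whether a non-aromatic group such as cyclohexyl on the amine nitrogen would fit this flat picture.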